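Adding (ethoxycarbonyl)methyl to the oxygen of compound 1

The compounds below may be only part of what the source reports. "The series", "measured", "known", "first", "only" and "open" are said of these compounds alone.

Compound 1 `CCOC(=O)c1c(C)nc(-c2cccc(C#N)c2)n1O` gives 17600 nM in a functional assay on a cell-free system (plasma, Oryctolagus cuniculus) for inhibition, with stated times of 5 min, 1 min and 6 min (a lower number here means a stronger inhibitor, a higher number a weaker inhibitor), and this is the starting point here. Two relatives help to place it. Compound 2 `CCOC(=O)c1c(C)nc(-c2cccc(C#N)c2)n1C`, with methyl in place of hydroxy on an aromatic nitrogen, gives 22100 nM, and the gap, a 1.3-fold higher number from compound 1 to compound 2 (0.10 log units; within the scatter), does not separate the two. Compound 3 `CCOCCOn1c(-c2cccc(C#N)c2)nc(C)c1C(=O)OCC` gives 6250 nM, so compound 1 sits level with compound 2 and on the weaker side of compound 3.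

The new compound 4 `CCOC(=O)COn1c(-c2cccc(C#N)c2)nc(C)c1C(=O)OCC` keeps the core of compound 1 and carries (ethoxycarbonyl)methyl in place of hydrogen on an oxygen on an aromatic ring.

Among the measured compounds shown here, the closest precedent is compound 3, which also replaces that hydrogen, here with 2-ethoxyethyl, and the result was a 2.8-fold lower number from compound 1 to compound 3 (0.45 log units; beyond the scatter). The step of a 3.5-fold lower number from compound 2 to compound 3 (0.55 log units; beyond the scatter) points the same way but starts from a different compound, so it is weaker support. For the measured compounds named here, no measured compound carries the (ethoxycarbonyl)methyl group, and a single precedent is thin evidence, so a modest drop is the reasonable expectation. The change expected in this assay is a 2.2-fold lower number from compound 1 to compound 4 (0.34 log units; beyond the scatter), a little smaller than the precedent. For compound 4 the estimated value is 8000 nM, with an expected range from 3000 nM to 20000 nM.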

Compound 4, half-maximal inhibitory concentration: 6800 nM
The estimate for compound 4 lay 1.2-fold (0.07 log units) above the measured number, and the stated range covers the measured number.
By their numbers in this assay, from the lowest: compounds 3 and 4 (each within the scatter of the next); then compounds 1 and 2 (each within the scatter of the next).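

With a 2.6-fold lower number from compound 1 to compound 4 (0.41 log units; beyond the scatter) in this assay and a 3.3-fold lower number from compound 2 to compound 4 (0.51 log units; beyond the scatter) in the same assay, the oxygen on the aromatic ring now has a second chain that gives a lower number, so the effect seen with compound 3 is not tied to 2-ethoxyethyl alone. The two chains themselves cannot be told apart: a 1.1-fold higher number from compound 3 to compound 4 (0.04 log units; within the scatter) in this assay shows that ethoxycarbonyl in place of ethoxymethyl on the chain carbon bound to that oxygen makes no readable difference, even though only one of the two chains carries a carbonyl. Nothing available here accounts for the lower numbers given by these two chains.

The compounds shown leave open whether a plain methyl or ethyl on that oxygen would also reach the level of compounds 3 and 4, or whether the chain needs the further oxygen atoms that both of these carry. From the compounds shown here alone, it also remains open how a longer chain, a carboxylic acid in place of the ethyl ester at the chain end, or an amine at that end would behave.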